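A few compounds are considered here, and "the series" means these few. Any claim that something is new, unique, unknown or untested is made for them only; others in the source may bear on it.

Of the compounds shown here, three sharing one core have been measured in a functional assay on MCF7 cells (Homo sapiens) for antiproliferative activity, read by MTT assay, with a stated time of 48 h, tested at 50 uM; a higher number here means a weaker effect of the compound at the concentration tested, a lower number a stronger effect. Compound 1 `COc1cccc(C(O)CCn2nc3c(Br)c(Br)c(Br)c(Br)c3n2)c1` gives 20% in this assay, and compound 2 `OC(CCn1nc2c(Br)c(Br)c(Br)c(Br)c2n1)c1cccc(Cl)c1` gives 12%. Going by the values given here, the only single-point step among the measured compounds, a number 8 percentage points lower from compound 1 to compound 2 (within the scatter), lies within the scatter, so these two numbers cannot be ordered. Compound 3 `C[C@@H](O)CCn1nc2c(Br)c(Br)c(Br)c(Br)c2n1` stands apart: in this assay compound 3 gives 64%, the highest of the three numbers, separated from compound 1 and from compound 2 by gaps beyond the scatter.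

Compound 4 `C[C@H](O)CCn1nc2c(Br)c(Br)c(Br)c(Br)c2n1` has not yet been measured. It differs from compound 3 in one place: the two compounds have the same atoms and bonds and differ only in configuration as drawn: 1 of 1 stereo elements differ; a stereocentre at a saturated chain carbon is drawn R in compound 3 and S in compound 4. Among the compounds with values here, none of the measured steps bears on this kind of change; the single measured step, from compound 1 to compound 2, concerns an aromatic substituent rather than configuration, and was itself within the scatter. There is thus no measured ground for expecting movement in either direction, and the expectation is of no step beyond the scatter, a number 2 percentage points lower from compound 3 to compound 4 (within the scatter). On that basis compound 4 is estimated at 62% in this assay, with a range from 40% to 85%.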

Compound 4, a percentage reported as activity, at one concentration (the size of the read-out at that concentration, not a potency): 87%
Beside the measured number, compound 4's estimate is 25 percentage points below it, and the stated range ends below it.
By their numbers in this assay, from the lowest: compounds 2 and 1 (each within the scatter of the next); then compound 3; then compound 4.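

Going by these compounds alone, until now, no measured step bore on configuration, and the only step available concerned an aromatic substituent and stayed within the scatter. In this assay, within the data shown here, the new pair gives the first step beyond the scatter between two compounds differing in one place, a number 23 percentage points higher from compound 3 to compound 4 (beyond the scatter), so the drawn configuration at this saturated chain carbon does matter here, with the S form showing the weaker effect at the concentration tested. The step can be assigned to this stereocentre alone because nothing else changes between the two structures: the fact that compounds 3 and 4 differ only in the configuration as drawn.

The step is a single modest difference at one concentration, so it gives no potency for either form, and compounds 1 and 2 are drawn without a configuration at their stereocentre, which leaves open whether the same preference would hold with an aromatic ring on that carbon. The compounds shown also leave open whether the preference would survive with an amine in place of the hydroxyl group, or with a longer chain joining that carbon to the shared core.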